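The source may hold more compounds than are shown below. What is called first, only, known or untested is meant among the compounds shown, and "the series" means these compounds.

Three compounds in the series carry numbers in a functional assay on NCI-H460 cells (Homo sapiens) for antiproliferative activity, read by trypan blue exclusion, with a stated time of 24 h; on this read-out higher numbers stand for weaker inhibition and lower numbers for stronger inhibition. Compound 1 `N#Cc1ccc(Cn2cc(/C=C3\NC(=O)NC3=O)c3ccccc32)cc1` gives 19100 nM. Compound 2 `Cc1ccc2c(c1)c(/C=C1\NC(=O)NC1=O)cn2Cc1ccccc1` gives 14600 nM, and compound 3 `COc1ccc2c(c1)c(/C=C1\NC(=O)NC1=O)cn2Cc1ccccc1` gives 28400 nM. On these numbers compound 1 stands second highest of the three; its nearest neighbour is compound 2 and its furthest compound 3, and both gaps lie within the scatter, so no order among the three can be read from them. For the measured compounds named here, the only single-point step between measured compounds is a 1.9-fold higher number from compound 2 to compound 3 (0.29 log units; within the scatter), a change on the shared core rather than on the benzyl ring, and it stays within the scatter.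

Compound 4 `Cc1ccc(Cn2cc(/C=C3\NC(=O)NC3=O)c3ccccc32)cc1` is not yet measured in this assay. It differs from compound 1 by methyl in place of cyano on an aromatic carbon. Going by the values given here, no measured pair alters the substituent on the benzyl ring, so the expectation rests only on compound 1 with 19100 nM and on the absence of any step beyond the scatter among the measured compounds. The expected step is therefore a 1.1-fold lower number from compound 1 to compound 4 (0.05 log units; within the scatter), meaning no change beyond the scatter is anticipated. Compound 4 is accordingly estimated at 17000 nM in this assay, within a range from 7500 nM to 40000 nM.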

Compound 4, half-maximal inhibitory concentration: 26100 nM
Compound 4: middle estimate off by 1.5-fold (0.19 log units), on the low side, and the stated range covers the measured number.
By their numbers in this assay, from the lowest: compounds 2, 1, 4 and 3 (each within the scatter of the next).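

With 4-cyanophenyl exchanged for 4-methylphenyl, a measured step now reaches the substituent para to a large group, which neither earlier compound pair had touched. In this assay this gives a 1.4-fold higher number from compound 1 to compound 4 (0.14 log units; within the scatter), so at this position the exchange of a nitrile for a methyl, which removes a triple bond and a hydrogen-bond acceptor, does not move the number beyond the scatter. Nothing in the data on hand accounts for this result or says what the two groups contribute to it.

Going by these compounds, the step covers only these two substituents at one place, so it remains open whether an amine, a carboxylic acid or a longer alkyl chain at the same position would shift the number beyond the scatter. For the compounds shown here, also open is whether the flat result on the 4-substituted phenyl ring would hold with methyl or methoxy on the shared core, since the only step measured there, a 1.9-fold higher number from compound 2 to compound 3 (0.29 log units; within the scatter), was taken with an unsubstituted benzyl group.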